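Pyridine to Imidazole on an Anilinomethyl Fatty Acid Receptor Agonist

The source may report more compounds than this note shows. Statements on the series, on what has been measured and on what is new or still open speak of the compounds shown alone.

Compound 1 `O=C(O)CCc1ccc(NCc2ccc(Cl)s2)cc1`: 143%
Compound 2 `O=C(O)CCc1ccc(NCc2cccnc2)cc1`: 4%

In a functional assay on CHO cells for agonist activity at Free fatty acid receptor 1 (Homo sapiens), read by reporter gene assay (on this read-out higher numbers stand for larger maximal responses and lower numbers for smaller maximal responses), compound 2 stands lowest of the two numbers; its nearest neighbour is compound 1, reached through the change a number 139 percentage points lower from compound 1 to compound 2 (beyond the scatter), a large drop. Compound 3 `O=C(O)CCc1ccc(NCc2ncc[nH]2)cc1` differs from compound 2 by 1H-imidazol-2-yl in place of pyridin-3-yl on a saturated chain carbon bound to a nitrogen on an aromatic ring. Among the measured compounds shown here, only that single step bears on the new change, and it gives no sign that a further small nitrogen-containing aromatic ring in this place would restore the response seen for compound 1. For compound 3 the expected step is a number 6 percentage points higher from compound 2 to compound 3 (within the scatter), within the scatter. Compound 3 is expected to give 10%, in the range 0% to 45%.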

Compound 3, largest response reached (reported as percent of maximum), in percent of the reference or control that the assay uses: 4%
For compound 3 the middle estimate is 6 percentage points above the measured one; the range from low to high includes it.
By their numbers in this assay, from the lowest: compounds 2 and 3 (each within the scatter of the next); then compound 1.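

In this assay, 1H-imidazol-2-yl in place of pyridin-3-yl gives no change at the digits printed from compound 2 to compound 3 (within the scatter) and so a five-membered aromatic ring with 2 hetero atoms and a hydrogen-bond donor reads the same here as the six-membered ring. Set against the 5-chlorothiophen-2-yl compound, the imidazole gives a number 139 percentage points lower from compound 1 to compound 3 (beyond the scatter) and so the large loss now appears with two different nitrogen-containing rings at this place. Nothing measured here bears on the reason for that loss.

Going by these compounds, whether the response of compound 1 rests on the chlorine or on the thiophene ring stays open. An unsubstituted thiophen-2-yl or a 4-chlorophenyl group on the same chain carbon would separate the two.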